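The source may report more compounds than this note shows. Statements on the series, on what has been measured and on what is new or still open speak of the compounds shown alone.

The four compounds share one core and differ in the sulfonamide part. Compound 1 `COc1ccc(S(=O)(=O)N2CCC(CCC(=O)c3cc(Cl)c(N)cc3OC)CC2)cc1` is recorded in an assay on brain for displacement of a labelled ligand from 5-hydroxytryptamine receptor 4 (Cavia porcellus), with a stated time of 30 min, in the presence of a further agent that is not named here (on this read-out higher numbers stand for weaker inhibition and lower numbers for stronger inhibition), as "not determined" (no result reported). Compound 2 `COc1ccc(S(=O)(=O)NCCCN2CCC(CCC(=O)c3cc(Cl)c(N)cc3OC)CC2)cc1` gives 26 nM in this assay. Among the measured compounds shown here, compound 3 `COc1cc(N)c(Cl)cc1C(=O)CCC1CCN(CCNS(=O)(=O)c2cc(Br)ccc2Br)CC1` gives 16.3 nM in this assay, which is the lower of the two numbers known so far, though its gap to compound 2 lies within the scatter of repeated measurements, so the two values cannot be separated.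

Compound 4 `COc1ccc(S(=O)(=O)NCCN2CCC(CCC(=O)c3cc(Cl)c(N)cc3OC)CC2)cc1OC` has not yet been measured. Relative to compound 3 its only change is 3,4-dimethoxyphenyl in place of 2,5-dibromophenyl on a sulfonyl sulfur. For the measured compounds named here, no step between two measured compounds shows the effect of such a change on the aryl group, so the expectation rests on the general level of compound 2 and compound 3 alone. Because compound 2, which carries a single methoxy group on its aryl ring, gives 26 nM, a 3,4-dimethoxyphenyl is expected to land in the same region. The step expected from compound 3 to compound 4 is a 1.8-fold higher number from compound 3 to compound 4 (0.26 log units; within the scatter), a small move toward higher numbers that may not rise beyond the scatter. Compound 4 is therefore estimated at 30 nM in this assay, with a plausible range from 8 nM to 120 nM.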

Compound 4, inhibition constant: 8.2 nM
The estimate for compound 4 lay 3.7-fold (0.56 log units) above the measured number, within the range that was stated.
By their numbers in this assay, from the lowest: compounds 4, 3 and 2 (each within the scatter of the next, the first and the last beyond it).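

On the sulfonyl sulfur, whose other neighbour is the sulfonamide nitrogen, 3,4-dimethoxyphenyl in place of 2,5-dibromophenyl gives a 2.0-fold lower number from compound 3 to compound 4 (0.30 log units; within the scatter) in this assay, so the two aryl groups cannot be separated on this read-out. This is the first step shown for the aryl group at this place, and it shows that the read-out stays within the scatter even though the group with 8 heavy atoms, 2 of them bromine, and no hydrogen-bond acceptors gives way to one with 10 heavy atoms, 2 of them oxygen, and 2 hydrogen-bond acceptors, while the six-membered aromatic ring of carbon only remains. No measurement given here accounts for this outcome.

From the compounds shown here alone, the step exchanges both substituents of the aryl group at once, so what a single methoxy group or a single bromine contributes at this place stays open. Also open, going by these compounds, is whether a plain phenyl, a pyridine or a phenyl carrying an amine or a carboxylic acid on the sulfonyl sulfur would stay within the scatter of compound 3 and compound 4.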